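Benzylamine aryl variation in the bis(trifluoromethyl)sulfonamide series

The source may hold more compounds than are shown below. What is called first, only, known or untested is meant among the compounds shown, and "the series" means these compounds.

Going by the values given here, compound 3 `O=S(=O)(NCCCNCc1ccc(Cl)c(C(F)(F)F)c1)c1cc(C(F)(F)F)cc(C(F)(F)F)c1` gives 10000 nM in a functional assay on PANC-1 cells (Homo sapiens) for inhibition, read by MTT assay, with a stated time of 72 h (on this read-out lower numbers stand for stronger inhibition of growth and higher numbers for weaker inhibition of growth), the highest of the three numbers so far; compound 2 `O=S(=O)(NCCCNCc1ccc(Cl)c(Cl)c1)c1cc(C(F)(F)F)cc(C(F)(F)F)c1` sits nearest with 5600 nM, and compound 1 `CC(C)(C)c1ccc(CNCCCNS(=O)(=O)c2cc(C(F)(F)F)cc(C(F)(F)F)c2)cc1` furthest with 2500 nM. The measured steps are a 2.2-fold higher number from compound 1 to compound 2 (0.35 log units; beyond the scatter), a 4.0-fold higher number from compound 1 to compound 3 (0.60 log units; beyond the scatter) and a 1.8-fold higher number from compound 2 to compound 3 (0.25 log units; within the scatter). Compound 4 `O=S(=O)(NCCCNCc1ccc(C(F)(F)F)cc1)c1cc(C(F)(F)F)cc(C(F)(F)F)c1` differs from compound 3 by 4-(trifluoromethyl)phenyl in place of 4-chloro-3-(trifluoromethyl)phenyl on a saturated chain carbon bound to an amine nitrogen. Among the compounds with values here, no measured step removes a chloro alone; the two aryl swaps from compound 1 were modest, and the chloro-to-trifluoromethyl exchange from compound 2 to compound 3 stayed within scatter. A small move toward a lower number, or none beyond the scatter, is therefore expected, a 1.7-fold lower number from compound 3 to compound 4 (0.22 log units; within the scatter). Compound 4 is estimated at 6000 nM in this assay, within 2500 nM to 15000 nM.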

Compound 4, concentration for 50% growth inhibition: 3200 nM
Beside the measured number, compound 4's estimate is 1.9-fold (0.27 log units) above it, within the range that was stated.
By their numbers in this assay, from the lowest: compounds 1, 4, 2 and 3 (each within the scatter of the next, the first and the last beyond it).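

In this assay, 4-(trifluoromethyl)phenyl in place of 4-chloro-3-(trifluoromethyl)phenyl gives a 3.1-fold lower number from compound 3 to compound 4 (0.49 log units; beyond the scatter), so the aryl substitution pattern at this position matters even though both groups carry a trifluoromethyl. Against the other two aryl groups the new group is not resolved: a 1.8-fold lower number from compound 2 to compound 4 (0.24 log units; within the scatter) and a 1.3-fold higher number from compound 1 to compound 4 (0.11 log units; within the scatter) both lie within the scatter, so trifluoromethyl in place of tert-butyl on an aromatic carbon shows no separable effect here. No supporting data are available to explain these steps.

Still open, on these data alone, is how an unsubstituted phenyl, a 4-methoxyphenyl or a pyridyl group would read at this position.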